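A few compounds are considered here, and "the series" means these few. Any claim that something is new, unique, unknown or untested is made for them only; others in the source may bear on it.

The compounds described here were all tested in a functional assay on Raji cells (Homo sapiens) for cytotoxicity, with a stated time of 72 h; a lower number here means that less compound is needed, a higher number that more compound is needed for the effect. Compound 1 `C=C[C@@](C)(/C=C/c1ccc(OCc2ccccc2)cc1)CCC=C(C)C` carries a benzyloxy group on the shared core. In this assay compound 1 gives > 26000 nM, and that figure is a limit of the assay rather than a measured number. Compound 2 `C=C[C@@](C)(/C=C/c1ccc(O)cc1)CCC(O)C(C)(C)O` likewise reaches only a limit in this assay, giving > 26000 nM. Within the data shown here, compound 3 `COc1ccc(/C=C/[C@@](C)(/C=C/c2ccc(O)c(C=O)c2)CCC=C(C)C)cc1` is the one compound of the three that returns a number, giving 13000 nM in this assay. Compound 1 therefore stands at the limit of > 26000 nM in this assay, at which 2 of the 3 values shown sit, alongside compound 2, while compound 3 sits not far from that limit.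

Compound 4 `C=C[C@@](C)(/C=C/c1ccc(Nc2ccc(Cl)c(Cl)c2)cc1)CCC=C(C)C` has not yet been measured. It differs from compound 1 in a single place: (3,4-dichlorophenyl)amino in place of benzyloxy on an aromatic carbon. Among the measured compounds shown here, no two measured compounds differ in only one place, so there is no measured step to lean on, and the available numbers are two limits and one weak value. In this assay compound 1 gives a limit, > 26000 nM. The step expected in this assay is an at least 1.7-fold lower number from compound 1 to compound 4 (0.23 log units; that floor lies within the scatter), a gain that may or may not exceed the usual scatter. Compound 4 is expected to give about 15000 nM in this assay, with a likely range from 5000 nM to 40000 nM, and a result reported again only as a limit would not be surprising.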

Compound 4, half-maximal effective concentration: > 26000 nM
Compound 4: a limit, no number; the forecaster's own chance of this, stated with the estimate: 45%; middle value at least 1.7-fold (0.23 log units) from the limit.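

In this assay compound 4 gives > 26000 nM as a limit, not a number. Compound 1 also reaches only a limit there, so no step can be read between compound 1 and compound 4. The compounds shown leave open whether (3,4-dichlorophenyl)amino or benzyloxy on the shared core gives the lower number.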